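Iodo Replaces Methoxy on the Shared Core

This account rests on a few compounds, and the source may have more. Where it says the series, first, only, none or still open, it means among the compounds named here.

In an assay on IMR-32 cells for displacement of a labelled ligand from corticotropin-releasing factor receptor 1 (Homo sapiens), read by scintillation counting, with a stated time of 2 h (on this read-out lower numbers stand for stronger inhibition and higher numbers for weaker inhibition), compound 1 `CCc1nc(NC(CC)CC)cnc1-c1ccc(Cl)cc1Cl` gives 545 nM, while compound 2 `CCc1nc(NC(CC)CC)c(OC)nc1-c1ccc(Cl)cc1Cl` gives 5.9 nM, the lowest of the two numbers, reached through a 92-fold lower number from compound 1 to compound 2 (1.97 log units; beyond the scatter). Compound 3 `CCc1nc(NC(CC)CC)c(I)nc1-c1ccc(Cl)cc1Cl` carries the change (iodo in place of methoxy on an aromatic carbon). Among the measured compounds shown here, no measured step swaps methoxy for iodo; the only step known is the one from compound 1 to compound 2, where a substituent entering at this aromatic carbon brought a large gain. A halogen at the same place is expected to keep most of that gain, so compound 3 is expected at 12 nM (range 2.5 nM to 60 nM), a step of a 2.0-fold higher number from compound 2 to compound 3 (0.31 log units; beyond the scatter) in this assay.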

Compound 3, inhibition constant: 12 nM
The estimate for compound 3 equals the measured number at the digits printed; measured number inside the range.
By their numbers in this assay, from the lowest: compound 2; then compound 3; then compound 1.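

Iodo, with no oxygen and no hydrogen-bond acceptor, still brings a 45-fold lower number from compound 1 to compound 3 (1.66 log units; beyond the scatter) in this assay, so the gain at this aromatic carbon does not belong to methoxy alone. Exchanging the two groups costs much less, with a 2.0-fold higher number from compound 2 to compound 3 (0.31 log units; beyond the scatter), and most of the gain stays. No evidence at hand bears on why this is so. On these data alone, it remains open how fluoro, an amine or a longer ethoxy chain would fare at this carbon. As far as these compounds go, it is also open whether the gain from iodo holds with another group in place of the (pentan-3-yl)amino group.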